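Para-fluoro benzamide analogue of a phenol-bearing pyrazole series

A few compounds are considered here, and "the series" means these few. Any claim that something is new, unique, unknown or untested is made for them only; others in the source may bear on it.

Measured so far:
compound 1 `COc1cccc(-c2nn(-c3ccccc3)cc2-c2ccnc(NCCCNC(=O)Nc3ccc(Cl)c(Cl)c3)c2)c1` — 5850 nM
compound 2 `O=C(NCCCNc1cc(-c2cn(-c3ccccc3)nc2-c2cccc(O)c2)ccn1)c1ccccc1` — "not determined" (no result reported) in a functional assay on K562 cells (Homo sapiens) for inhibition; on this read-out higher numbers stand for weaker inhibition of growth and lower numbers for stronger inhibition of growth

Compound 2 stands without a number: in this assay compound 1 gives 5850 nM, but for compound 2 nothing was determined, so there is no anchor on its own scaffold. Compound 3 `O=C(NCCCNc1cc(-c2cn(-c3ccccc3)nc2-c2cccc(O)c2)ccn1)c1ccc(F)cc1` differs from compound 2 by fluoro in place of hydrogen on an aromatic carbon. A change of this size is expected to move the read-out in this assay by no more than the usual scatter, in no set direction. For compound 3 the concentration for total growth inhibition is estimated at 4000 nM, with a range from 800 nM to 20000 nM.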

Compound 3, concentration for total growth inhibition: 4830 nM
Compound 3: middle estimate off by 1.2-fold (0.08 log units), on the low side; the measured number falls inside the stated range.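

In this assay, for the compounds shown here, compound 2 has no number, so no step to compound 3 can be read. Going by these compounds, the effect of fluoro in place of hydrogen on this scaffold stays open. No evidence bears on this result.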